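Fluoro substitution across two cores in a cytotoxicity series

This account rests on a few compounds, and the source may have more. Where it says the series, first, only, none or still open, it means among the compounds named here.

Measured so far:
compound 1 `Cc1cc(=O)n(-c2ccc(F)cc2)nc1C(=O)Nc1ccc(Oc2ncnc3ccsc23)cc1` with 2360 nM
compound 2 `Cc1cc(=O)n(-c2ccc(F)cc2)nc1C(=O)Nc1ccc(Oc2ncnc3ccsc23)c(F)c1` with 580 nM
compound 3 `Cc1cc(=O)n(-c2ccc(F)cc2)nc1C(=O)Nc1ccc(Oc2ncnc3sccc23)cc1` with 7050 nM

All numbers come from a functional assay on A549 cells (Homo sapiens) for cytotoxicity, read by MTT assay, with a stated time of 72 h; on this read-out higher numbers stand for weaker inhibition and lower numbers for stronger inhibition. Compound 1 and compound 3 carry the same atoms joined differently; the two cores differ as a group of 9 heavy atoms (6 carbon, 2 nitrogen, 1 sulfur; one five-membered aromatic ring with 1 hetero atom, one six-membered aromatic ring with 2 hetero atoms) in place of a group of 9 heavy atoms (6 carbon, 2 nitrogen, 1 sulfur; one five-membered aromatic ring with 1 hetero atom, one six-membered aromatic ring with 2 hetero atoms), on an oxygen on an aromatic ring, and this gives a 3.0-fold higher number from compound 1 to compound 3 (0.48 log units; beyond the scatter). Compound 3 therefore stands highest of the three numbers.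

Within the core of compound 1, the change fluoro in place of hydrogen on an aromatic carbon gives a 4.1-fold lower number from compound 1 to compound 2 (0.61 log units; beyond the scatter).

Compound 4 `Cc1cc(=O)n(-c2ccc(F)c(F)c2)nc1C(=O)Nc1ccc(Oc2ncnc3sccc23)cc1` is not yet measured in this assay. It differs from compound 3 by fluoro in place of hydrogen on an aromatic carbon. The place is not the same as in compound 2: there the fluoro sits ortho to a large group and meta to a large group, here ortho to a fluoro group and meta to a large group, so this is the same kind of change, not the same change. The expected step is a 1.4-fold lower number from compound 3 to compound 4 (0.15 log units; within the scatter), set beside a 4.1-fold lower number from compound 1 to compound 2 (0.61 log units; beyond the scatter) and discounted from that earlier step, the place not being the same. Compound 4 is estimated at 5000 nM, expected between 2000 nM and 12000 nM.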

Compound 4, half-maximal inhibitory concentration: 13500 nM
Compound 4: the middle estimate sits 2.7-fold (0.43 log units) below what was measured; measured number above the stated range.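

In this assay, the change from 4-fluorophenyl to 3,4-difluorophenyl gives a 1.9-fold higher number from compound 3 to compound 4 (0.28 log units; within the scatter), so on this core the added fluoro has no readable effect. Fluoro in place of hydrogen on an aromatic carbon therefore cannot be carried from one core to the other in this series as a fixed step: the same change on two cores in this assay, a 4.1-fold lower number (0.61 log units; beyond the scatter) from compound 1 to compound 2 and a 1.9-fold higher number (0.28 log units; within the scatter) from compound 3 to compound 4, 7.8-fold (0.89 log units) apart, beyond the scatter of two such steps

What is not shown is whether the core or the place accounts for this gap: the fluoro in compound 2 stands ortho to a large group, the new fluoro in compound 4 stands ortho to a fluoro group, and each step rests on a single pair. Open, going by these compounds, is how fluoro behaves at the place in compound 2 on the core of compound 3, and at the place in compound 4 on the core of compound 1, the two comparisons that would separate core from place. Also open, on these data alone, is whether chloro or methoxy at these places would follow fluoro.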